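The source may report more compounds than this note shows. Statements on the series, on what has been measured and on what is new or still open speak of the compounds shown alone.

Among the measured compounds shown here, in a functional assay, tested at 200 ug/mL (on this read-out higher numbers stand for a stronger effect at the one concentration tested and lower numbers for a weaker effect), compound 2 `COc1ccc(C2C(C#N)=C(N)OC(c3c[nH]c4ccccc34)=C2C#N)cc1OC` gives 26.1%, the only number reported in this small set. For the measured compounds named here, compound 1 `N#CC1=C(N)OC(c2c[nH]c3ccccc23)=C(C#N)C1c1ccc2ccccc2c1` was reported in this assay as "not active" (no number reported), without a number, so no step between measured compounds can be sized. Compound 3 `N#CC1=C(N)OC(c2c[nH]c3ccccc23)=C(C#N)C1c1ccccc1` differs from compound 2 by phenyl in place of 3,4-dimethoxyphenyl on a saturated ring carbon. Going by the values given here, with no measured step to guide the size, a modest fall in this assay is expected, of about a number 11.1 percentage points lower from compound 2 to compound 3 (beyond the scatter), not clearly beyond the usual scatter. Compound 3 is expected to give about 15% in this assay, within a range from 0% to 35%.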

Compound 3, a percentage reported as activity, at one concentration (the size of the read-out at that concentration, not a potency): 24.5%
Beside the measured number, compound 3's estimate is 9.5 percentage points below it; the range from low to high includes it.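

In this assay, phenyl in place of 3,4-dimethoxyphenyl on the saturated ring carbon gives a number 1.6 percentage points lower from compound 2 to compound 3 (within the scatter), so compound 2 and compound 3 cannot be told apart on this read-out. At this position, the read-out therefore does not depend on the two methoxy groups or on the hydrogen-bond acceptors counted with them. Nothing shown offers an explanation for this result. The compounds shown leave open whether an amine or a carboxylic acid on this phenyl would move the read-out beyond the scatter.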